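Removing one hydroxy group from compound 1

The source may hold more compounds than are shown below. What is called first, only, known or untested is meant among the compounds shown, and "the series" means these compounds.

In a functional assay on RAW264.7 cells (Mus musculus) for inhibition (on this read-out lower numbers stand for stronger inhibition and higher numbers for weaker inhibition), compound 1 `CC(C)=CCC/C(C)=C/Cc1c(O)c2c(c(/C=C/C(=O)c3ccc(O)c(O)c3)c1O)OC(C)(C)C=C2` gives 9500 nM and compound 2 `COc1cccc(O)c1C(=O)/C=C/c1ccccc1` gives 9600 nM as its reading, so the two lie within the scatter of each other and neither stands out. Compound 3 `CC(C)=CCC/C(C)=C/Cc1c(O)c2c(c(/C=C/C(=O)c3ccc(O)cc3)c1O)OC(C)(C)C=C2` differs from compound 1 by a single change hydrogen in place of hydroxy on an aromatic carbon that turns 3,4-dihydroxyphenyl into 4-hydroxyphenyl. Among the compounds with values here, no measured pair shows what this change does, so the expected step of no change at the digits printed from compound 1 to compound 3 (within the scatter) is only an estimate, and it is expected to stay within the scatter, with neither direction favoured. Compound 3 is estimated at 9500 nM in a likely range of 3500 nM to 26000 nM for now.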

Compound 3, half-maximal inhibitory concentration: 7600 nM
Estimate against measurement, compound 3: 1.3-fold (0.10 log units) above, within the range that was stated.
By their numbers in this assay, from the lowest: compounds 3, 1 and 2 (each within the scatter of the next).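

In this assay, hydrogen in place of hydroxy gives a 1.3-fold lower number from compound 1 to compound 3 (0.10 log units; within the scatter) as 3,4-dihydroxyphenyl becomes 4-hydroxyphenyl. At this position, ortho to a hydroxy group, the hydroxy group can therefore go without a shift in the reading beyond the scatter. No measurement here explains this result.

As far as these compounds go, whether an amine or a carboxylic acid on this same aromatic carbon would shift the reading remains open. So does what happens when the remaining hydroxy group of 4-hydroxyphenyl also goes.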